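A few compounds are considered here, and "the series" means these few. Any claim that something is new, unique, unknown or untested is made for them only; others in the source may bear on it.

Measured so far in an ADME assay on THP-1 cells (Homo sapiens) for cytotoxicity, read by trypan blue exclusion, with a stated time of 24 h; on this read-out lower numbers stand for stronger inhibition and higher numbers for weaker inhibition:
Compound 1, `N#C[Se]c1ccc(N)cc1`, gives > 50000 nM.
Compound 2, `N#C[Se]Cc1ccc(C(F)(F)F)cc1`, gives 19800 nM.

Compound 1 gives > 50000 nM, which is a limit of the assay rather than a number; it sits at the limit of > 50000 nM in this assay, at which 1 of the 2 values shown sits. That leaves compound 2, with its value of 19800 nM, as the only plain number shown in this assay, so it has no measured neighbour to stand beside, and no step between measured compounds can be drawn from these two entries.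

The next compound, compound 3 with the structure `N#C[Se]Cc1ccc(C#N)cc1`, differs from compound 2 in one place: cyano in place of trifluoromethyl on an aromatic carbon. The trifluoromethyl group leaves and a cyano group enters. Among the compounds with values here, no measured pair with a change of this kind is available, so the size of such a step cannot be read from the data. Without such a guide, the step from compound 2 to compound 3 in this assay is expected to be a 1.3-fold higher number from compound 2 to compound 3 (0.10 log units; within the scatter), which is a change no larger than the usual scatter. On that basis compound 3 is estimated at 25000 nM, with a range from 8000 nM to 60000 nM, while the measured number itself is still to come.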

Compound 3, half-maximal inhibitory concentration: 7970 nM
Estimate against measurement, compound 3: 3.1-fold (0.50 log units) above; the whole stated range lies above it.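

Within the data shown here, for the first time there is a measured step in this assay: on an aromatic carbon, para to a group of 4 heavy atoms, cyano in place of trifluoromethyl gives a 2.5-fold lower number from compound 2 to compound 3 (0.40 log units; beyond the scatter) and so goes beyond the usual scatter. This shows that the number responds to the group at this position, and since a lower number stands for stronger inhibition, compound 3 is the more cytotoxic of this pair. The entering group has 2 heavy atoms against 4 and 1 hydrogen-bond acceptor against 0, but a single pair cannot separate these differences, and nothing measured here accounts for the step.

Compound 1 remains a limit of the assay and not a number, and no step can be read from it: the limit of > 50000 nM in this assay, at which 1 of the 3 values shown sits. Also open, going by these compounds, is how the number would respond to other groups at this position, such as a carboxylic acid or a methoxy group, and whether the step between cyano and trifluoromethyl would keep its size on another core.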